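Hydroxyazepane sulfonamides: cytotoxicity from compound 3 to compound 4

The source may hold more compounds than are shown below. What is called first, only, known or untested is meant among the compounds shown, and "the series" means these compounds.

Measured in an ADME assay on HepG2 2.2.15 cells (Homo sapiens) for cytotoxicity, read by luminescence, with a stated time of 3 days; on this read-out lower numbers stand for higher toxicity in this test and higher numbers for lower toxicity in this test:
- compound 1 `O=C(Nc1ccc(F)c(Cl)c1)c1ccc(F)c(S(=O)(=O)N2CCSCC(O)C2)c1`: 19000 nM
- compound 2 `O=C(Nc1ccc(F)c(Cl)c1)c1ccc(F)c(S(=O)(=O)N2CCCCC(O)CC2)c1`: 24000 nM
- compound 3 `O=C(Nc1ccc(F)c(Cl)c1)c1ccc(F)c(S(=O)(=O)N2CCCCC(CO)C2)c1`: 3100 nM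

Compound 3, at 3100 nM, gives the lowest of the three numbers, and it is the only one of them to carry a hydroxymethyl group. The next structure, compound 4 `O=C(Nc1ccc(F)c(Cl)c1)c1ccc(F)c(S(=O)(=O)N2CCCC(O)CC2)c1`, has 4-hydroxyazepan-1-yl in place of 3-(hydroxymethyl)azepan-1-yl on a sulfonyl sulfur. Its seven-membered ring stays, and the hydroxymethyl group gives way to a hydroxy group, as found in compound 1 and compound 2.

Within the data shown here, two measured steps bear on this: a 6.1-fold lower number from compound 1 to compound 3 (0.79 log units; beyond the scatter) and a 7.7-fold lower number from compound 2 to compound 3 (0.89 log units; beyond the scatter). The third, a 1.3-fold higher number from compound 1 to compound 2 (0.10 log units; within the scatter), shows no separation between those two hydroxy compounds despite their different rings. Among the measured compounds shown here, no measured pair swaps hydroxy for hydroxymethyl on an otherwise identical ring, so the comparison is indirect and rests on compound 3 alone. In this assay, a step of similar size in the reverse direction is therefore expected, towards a higher number. The expected step is a 5.5-fold higher number from compound 3 to compound 4 (0.74 log units; beyond the scatter). For compound 4 the estimate is 17000 nM, with an expected range of 7000 nM to 40000 nM.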

Compound 4, half-maximal cytotoxic concentration: 29000 nM
For compound 4 the middle estimate is 1.7-fold (0.23 log units) below the measured one; the range from low to high includes it.
By their numbers in this assay, from the lowest: compound 3; then compounds 1, 2 and 4 (each within the scatter of the next).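

In this assay, among these compounds, the swap of 3-(hydroxymethyl)azepan-1-yl for 4-hydroxyazepan-1-yl on the sulfonyl sulfur gives a 9.4-fold higher number from compound 3 to compound 4 (0.97 log units; beyond the scatter), and this is the first step in which both groups have a seven-membered non-aromatic ring with 1 hetero atom. The other two new steps, a 1.2-fold higher number from compound 2 to compound 4 (0.08 log units; within the scatter) and a 1.5-fold higher number from compound 1 to compound 4 (0.18 log units; within the scatter), leave compound 1, compound 2 and compound 4 unseparated, so among these hydroxy compounds the read-out does not distinguish the three rings, and compound 3 alone stands apart. The data offer no measurement that explains the step at this position.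

Two things change together from compound 3 to compound 4, the hydroxymethyl chain and the place of substitution on the ring, and the compounds shown do not divide the step between them. Still open, from the compounds shown here alone, is how 3-hydroxyazepan-1-yl and 4-(hydroxymethyl)azepan-1-yl would read, and whether an azepane bearing an amine or a carboxylic acid would stay with the hydroxy compounds or with compound 3.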